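Swapping a methoxy for a methylsulfanyl on compound 1

The source may report more compounds than this note shows. Statements on the series, on what has been measured and on what is new or still open speak of the compounds shown alone.

Of the compounds shown here, three of one family have been tested in a functional assay on HL-60 cells (Homo sapiens) for antiproliferative activity, read by MTT assay, with a stated time of 72 h; a lower number here means a stronger inhibitor, a higher number a weaker inhibitor. Going by the values given here, compound 1, `COc1ccc(-c2ncnn2-c2cc(OC)c(OC)c(OC)c2)cc1`, is the only one to return a number: in this assay compound 1 gives 120 nM. Compound 2, `CCOc1ccccc1-c1ncnn1-c1cc(OC)c(OC)c(OC)c1`, reaches only a limit of the measurement, > 10000 nM, rather than a number. Compound 3, `CCOc1cccc(-c2ncnn2-c2cc(OC)c(OC)c(OC)c2)c1`, likewise stops at a limit, > 10000 nM. So compound 1 stands alone with a measured value, while the other two sit at the limit of > 10000 nM in this assay, at which 2 of the 3 values shown sit.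

The next compound, compound 4, `COc1cc(-n2ncnc2-c2ccc(SC)cc2)cc(OC)c1OC`, keeps the whole framework of compound 1 and changes one group: methylsulfanyl in place of methoxy on an aromatic carbon. The methoxy leaves, the methylsulfanyl enters, and the site is the same aromatic carbon of the six-membered ring of carbon only.

Among the compounds with values here, no measured pair in this set differs in exactly one place, so no measured step can guide the size of this one. Given that compound 1 gives 120 nM and that the group which enters is of the same count of heavy atoms as the one it replaces, the expected step from compound 1 to compound 4 in this assay is a 1.2-fold lower number from compound 1 to compound 4 (0.08 log units; within the scatter), that is, no more than the usual scatter. For compound 4 the estimate in this assay is 100 nM, expected to fall between 30 nM and 400 nM.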

Compound 4, half-maximal inhibitory concentration: 500 nM
The estimate for compound 4 lay 5.0-fold (0.70 log units) below the measured number; the whole stated range lies below it.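

Placed on an aromatic carbon para to a large group, methylsulfanyl in place of methoxy gives a 4.2-fold higher number from compound 1 to compound 4 (0.62 log units; beyond the scatter) in this assay. Going by these compounds alone, this is the first single-change step in the set, and it shows that this site is sensitive to which group it carries, even though the two groups have the same number of heavy atoms and the same count of hydrogen-bond acceptors. The swap weakens the compound without removing its activity, since compound 4 still returns a measured value of 500 nM.

No measured property among the data shown accounts for the size of this step. Going by these compounds, it also remains open how this carbon would respond to other groups, such as an amine, a chlorine atom or a longer chain like propoxy, and whether any of them would match or improve on the methoxy of compound 1.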